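The compounds below may be only part of what the source reports. "The series", "measured", "known", "first", "only" and "open" are said of these compounds alone.

Compound 1 `CC(C)OC(=O)COC(=O)c1ccc([N+](=O)[O-])o1` gives > 100000 nM
Compound 2 `CC(=O)Oc1ccc(CN(C(=O)COC(=O)c2ccc([N+](=O)[O-])o2)C(C)(C)C)cc1` gives > 100000 nM
Compound 3 `CC(C)(C)N(Cc1ccc(OCc2ccccc2)cc1)C(=O)COC(=O)c1ccc([N+](=O)[O-])o1` gives "not active" (no number reported)

In an ADME assay on MT4 cells (Homo sapiens) for cytotoxicity, read by MTT assay, with a stated time of 3 days (a higher number here means that more compound is tolerated, a lower number that less compound is tolerated), compound 2 gives > 100000 nM, which is a limit of the assay and not a number. Compound 1 gives > 100000 nM, and this too is a limit. Compound 3 is reported as "not active" (no number reported), with no number attached. The set therefore offers (the limit of > 100000 nM in this assay, at which 2 of the 3 values shown sit), so compound 2 cannot be ranked against the other two.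

Compound 4 `CC(C)(C)N(Cc1cccc(C(F)(F)F)c1)C(=O)COC(=O)c1ccc([N+](=O)[O-])o1` has not yet been measured in this assay. It carries 3-(trifluoromethyl)phenyl in place of 4-acetoxyphenyl on a saturated chain carbon bound to an amide-type nitrogen, and the count of that change reads (3-(trifluoromethyl)phenyl in place of 4-acetoxyphenyl on a saturated chain carbon bound to an amide-type nitrogen). The rest of the structure of compound 2 stays as it is.

Among the measured compounds shown here, no measured step between two compounds is available as a guide, so the expectation rests on compound 2 and its limit of > 100000 nM alone. No step beyond the scatter is expected, and any small shift would be towards less compound being tolerated. The expected step is an at least 1.2-fold lower number from compound 2 to compound 4 (0.09 log units; that floor lies within the scatter), an estimate that stays within the scatter. For compound 4 the estimated half-maximal cytotoxic concentration is 80000 nM, with an expected range of 25000 nM to 100000 nM, and the result may well be only a limit again.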

Compound 4, half-maximal cytotoxic concentration: > 100000 nM
Compound 4: a limit, no number; the forecaster's own chance of this, stated with the estimate: 65%; at least 1.2-fold (0.09 log units) between middle value and limit.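

In this assay compound 4 gives > 100000 nM, which is a limit of the assay and not a number. Compound 2 is also reported only as a limit, so no step can be read between compound 2 and compound 4: the limit of > 100000 nM in this assay, at which 3 of the 4 values shown sit.

The compounds shown leave open whether 3-(trifluoromethyl)phenyl in place of 4-acetoxyphenyl changes how much compound is tolerated, and at what concentration compound 2 or compound 4 would become cytotoxic.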